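The compounds below may be only part of what the source reports. "The series", "measured", "known", "first", "only" and "open" are said of these compounds alone.

Working notes on the series. Compound 1 `Nc1ccccc1NC(=O)CCCCCN(CC(=O)NC1CCCCC1)C(=O)c1ccccc1` in an assay on Sf9 cells for inhibition of protein deacetylase HDAC6 (Homo sapiens), read by fluorescence, with a stated time of 90 min (a higher number here means a weaker inhibitor, a lower number a stronger inhibitor), gives only a limit, > 10000 nM. Compound 2 `Cc1cc(C)cc(CNC(=O)CN(CCCCCC(=O)Nc2ccccc2N)C(=O)c2cc(C)cc(C)c2)c1` in this assay likewise gives only a limit, > 10000 nM. Compound 3 `Cc1ccc(CNC(=O)CN(CCCCCC(=O)Nc2ccccc2N)C(=O)c2cc(C)cc(C)c2)cc1` in this assay also returns only a limit, > 10000 nM. Compound 3 therefore stands at the same limit as the others, which is the limit of > 10000 nM in this assay, at which 3 of the 3 values shown sit. Among the compounds with values here, the single one-place step so far, a step that the two limits leave unreadable from compound 2 to compound 3, is unreadable between two limits. Compound 4 `Cc1cc(C)cc(C(=O)N(CCCCCC(=O)Nc2ccccc2N)CC(=O)NC2CCCCC2)c1` differs from compound 3 by cyclohexyl in place of 4-methylbenzyl on an amide-type nitrogen. Within the data shown here, no measured step bears on this change directly, and the cyclohexylcarbamoyl arm already present in compound 1 sat at the limit. The step that the limit leaves unreadable from compound 3 to compound 4 is expected to be none beyond the scatter. Compound 4 is thus estimated at 20000 nM, within 5000 nM to 80000 nM, most likely again as a limit in this assay.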

Compound 4, half-maximal inhibitory concentration: > 10000 nM
Compound 4 was reported as a limit (the forecaster's own chance of this, stated with the estimate: 80%); the middle value does not contradict the limit.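

No step can be read between compound 4 and compound 1, compound 2 or compound 3, as each is reported only as a limit in this assay: the limit of > 10000 nM in this assay, at which 4 of the 4 values shown sit.

The compounds shown leave open how large any of these steps is, and which change, if any, would give a measured value in this assay.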